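The compounds below may be only part of what the source reports. "The series", "measured", "known", "first", "only" and "open" are said of these compounds alone.

Series so far, in a functional assay on DU-145 cells (Homo sapiens) for cytotoxicity, read by sulforhodamine B assay, with a stated time of 72 h; a lower number here means that less compound is needed, a higher number that more compound is needed for the effect:
- compound 1 `CCOc1cccc(-c2cc3occ(C)c3c(=O)o2)c1`: 74.1 uM
- compound 2 `Cc1coc2cc(-c3cccc(O)c3)oc(=O)c12`: 82.6 uM
- compound 3 `Cc1coc2cc(-c3ccc(O)c(O)c3)oc(=O)c12`: not yet measured

Compound 2, at 82.6 uM, stands level with compound 1, as the two values lie within the scatter of each other. The next change starts from compound 2 and gives compound 3: hydroxy in place of hydrogen on an aromatic carbon. This is hydroxy in place of hydrogen on an aromatic carbon, ortho to a hydroxy group and para to a large group.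

Going by the values given here, only one measured step bears on it: a 1.1-fold higher number from compound 1 to compound 2 (0.05 log units; within the scatter), for hydrogen in place of ethyl on an oxygen on an aromatic ring. Among the compounds with values here, that step is small, but it is a different change, and no measured step adds a hydroxy group. No shift beyond the scatter is therefore expected in this assay, with only a slight lean towards a lower number. The expected change is a 1.4-fold lower number from compound 2 to compound 3 (0.14 log units; within the scatter). For compound 3 the estimated value is 60 uM, with an expected range of 25 uM to 120 uM.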

Compound 3, concentration for half-maximal effect: 25.6 uM
Compound 3: middle estimate off by 2.3-fold (0.37 log units), on the high side; the range from low to high includes it.
By their numbers in this assay, from the lowest: compound 3; then compounds 1 and 2 (each within the scatter of the next).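

In this assay, hydroxy in place of hydrogen on an aromatic carbon, ortho to a hydroxy group and para to a large group, gives a 3.2-fold lower number from compound 2 to compound 3 (0.51 log units; beyond the scatter). This is the only step among the compounds shown that lies beyond the scatter, whereas hydrogen in place of ethyl on the oxygen of the same aromatic ring gave a 1.1-fold higher number from compound 1 to compound 2 (0.05 log units; within the scatter), so this ring position responds to the added hydroxy group, though only modestly. No supporting data bear on what lies behind this step.

As far as these compounds go, whether a methoxy group, an amine or a fluorine atom on the same aromatic carbon would give a similar step remains open. Also open, from the compounds shown here alone, is whether the step depends on the existing hydroxy group, or would persist with an ethoxy group in its place.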